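A few compounds are considered here, and "the series" means these few. Any claim that something is new, unique, unknown or untested is made for them only; others in the source may bear on it.

Working notes on the series. In a functional assay on THP-1 cells (Homo sapiens) for inhibition, read by sulforhodamine B assay, with a stated time of 48 h, tested at 50 uM (on this read-out lower numbers stand for less inhibition of growth and higher numbers for more inhibition of growth at the one concentration tested), compound 1 (`COc1cc(/C=C/C(=O)/C=C/c2cccc3ccccc23)ccc1OCc1cn(CCOc2cc(=O)oc3ccccc23)nn1`) gives 89% and compound 2 (`COc1cc(/C=C/C(=O)/C=C/c2cccc3ccccc23)ccc1OCc1cn(CCCOc2cc(=O)oc3ccccc23)nn1`) gives 71%. Compound 1 is the higher of these two, and the gap between them lies beyond the scatter. Compound 3 (`COc1cccc(/C=C/C(=O)/C=C/c2ccc(OCc3cn(CCOc4cc(=O)oc5ccccc45)nn3)c(OC)c2)c1`) has not yet been measured in this assay. It differs from compound 1 in one place, on a double-bonded chain carbon bound to a double-bonded chain carbon, where 3-methoxyphenyl stands in place of naphthalen-1-yl: 3-methoxyphenyl in place of naphthalen-1-yl on a double-bonded chain carbon bound to a double-bonded chain carbon. Within the data shown here, no measured pair shows the effect of this exchange, so the expectation rests on thin evidence. With compound 1 at 89%, there is little room for a rise on this read-out, so a moderate fall is the more likely direction, although no change beyond the scatter remains possible. A fall of about the size of the gap between compound 1 and compound 2 is a reasonable working guess. The expected change is a number 14 percentage points lower from compound 1 to compound 3 (beyond the scatter). For compound 3, the estimated value is 75%, with an expected range of 55% to 93%.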

Compound 3, percent growth inhibition at one concentration: 77%
Estimate against measurement, compound 3: 2 percentage points below; measured number inside the range.
By their numbers in this assay, from the lowest: compounds 2 and 3 (each within the scatter of the next); then compound 1.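

In this assay, among these compounds, replacing naphthalen-1-yl with 3-methoxyphenyl on a double-bonded chain carbon bound to a double-bonded chain carbon gives a number 12 percentage points lower from compound 1 to compound 3 (beyond the scatter), the first reading at this position, as compound 1 and compound 2 both carry naphthalen-1-yl there. The position therefore responds to this change, yet a substantial reading remains, with compound 3 at 77%, so a naphthalen-1-yl group is not required there for growth inhibition at the one concentration tested. The exchange removes one six-membered aromatic ring and adds one hydrogen-bond acceptor in a single step, and no available measurement explains the fall or assigns it to either difference.

The compounds shown leave open whether an unsubstituted phenyl, or a phenyl bearing an amine or a carboxylic acid, would read closer to compound 1 or to compound 3, which would help separate the ring change from the methoxy group. They also leave open whether the same exchange would produce a step of similar size on the core of compound 2, which has the longer chain.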